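Isopropyl to pentafluoroethyl on the shared core

The source may report more compounds than this note shows. Statements on the series, on what has been measured and on what is new or still open speak of the compounds shown alone.

Measured so far in a physicochemical assay for solubility, measured as kinetic solubility, at pH 7.4 (a lower number here means a less soluble compound, a higher number a more soluble compound), for two compounds
compound 1 `CN1C(=O)[C@@H](NC(=O)c2n[nH]c3ncc(C(F)(F)F)cc23)COc2ccccc21` gives 59000 nM
compound 2 `CC(C)c1cnc2[nH]nc(C(=O)N[C@H]3COc4ccccc4N(C)C3=O)c2c1` gives 3400 nM

Compound 2 at 3400 nM holds the lower of the two measured numbers. The next compound is compound 3 `CN1C(=O)[C@@H](NC(=O)c2n[nH]c3ncc(C(F)(F)C(F)(F)F)cc23)COc2ccccc21` which is still unmeasured. Its difference from compound 2 is 1,1,2,2,2-pentafluoroethyl in place of isopropyl on an aromatic carbon and so 1,1,2,2,2-pentafluoroethyl takes the place of isopropyl on an aromatic carbon.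

Among the measured compounds shown here, one measured step bears on this change: a 17-fold lower number from compound 1 to compound 2 (1.24 log units; beyond the scatter) which is large and beyond the scatter. That step brought isopropyl in place of trifluoromethyl, while here isopropyl leaves again for a different fluorine-bearing group. For the measured compounds named here, no measured compound carries pentafluoroethyl, so the earlier step is only a partial guide, and just part of it is expected to return. A modest move to a higher number is therefore expected, estimated as a 2.6-fold higher number from compound 2 to compound 3 (0.42 log units; beyond the scatter) in this assay and smaller than the earlier step. For compound 3 the expected value is 9000 nM within an estimated range from 2000 nM to 40000 nM until the measurement is in.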

Compound 3, solubility: 17000 nM
Estimate against measurement, compound 3: 1.9-fold (0.28 log units) below; low and high end bracket the measured number.
By their numbers in this assay, from the lowest: compound 2; then compound 3; then compound 1.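

In this assay the aromatic carbon of the shared core takes a second fluorine-bearing group, and 1,1,2,2,2-pentafluoroethyl in place of isopropyl gives a step beyond the scatter (a 5.0-fold higher number from compound 2 to compound 3 (0.70 log units; beyond the scatter)). Among the compounds shown here, both fluorine-bearing compounds now stand above compound 2, so across these three compounds the isopropyl compound holds the lowest number and no compound goes against that order. The two fluorine-bearing groups are not interchangeable either, since trifluoromethyl in place of fluoro on the saturated chain carbon gives a step that is also beyond the scatter (a 3.5-fold lower number from compound 1 to compound 3 (0.54 log units; beyond the scatter)), placing compound 3 between compound 2 and compound 1. No accompanying measurement bears on why the three compounds fall in this order.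

Where an amine, a methoxy group or a longer perfluorinated chain such as nonafluorobutyl would fall in this order at the same aromatic carbon stays open. Also open, on these data alone, is whether the same order of the three groups would hold on a core other than the shared core.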